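Amide Variation on the Shared Core, Compound 1 to Compound 4

The source may hold more compounds than are shown below. What is called first, only, known or untested is meant among the compounds shown, and "the series" means these compounds.

Among the measured compounds shown here, compound 1 `O=C(c1c(O)ccc2cc(-c3cccc(O)c3)ccc12)N1CCCCC1` is the only member of the series with a reported number: in an in vitro assay on Sf9 cells for inhibition of 17-beta-hydroxysteroid dehydrogenase type 1 (Homo sapiens), tested at 100 nM (a higher number here means a stronger effect of the compound at the concentration tested, a lower number a weaker effect), compound 1 gives 29%. Compound 2 `Cc1ccc(S(=O)(=O)c2c(O)ccc3cc(-c4cccc(O)c4)ccc23)cc1` belongs to the same series, but in this assay compound 2 has "not determined" (no result reported); likewise compound 3 `O=S(=O)(c1ccccc1)c1c(O)ccc2cc(-c3cccc(O)c3)ccc12` has "not determined" (no result reported) in this assay, so compound 1 cannot be ranked against either of them. Compound 4 `O=C(Nc1cccc(O)c1)c1c(O)ccc2cc(-c3cccc(O)c3)ccc12` has not been measured. It differs from compound 1 by (3-hydroxyphenyl)amino in place of piperidin-1-yl on a carbonyl carbon. For the measured compounds named here, no step between measured compounds is available to calibrate this change, so the expectation rests on compound 1 alone. A moderate gain in this assay is expected, a number 11 percentage points higher from compound 1 to compound 4 (beyond the scatter), given that compound 1 starts from 29%. Compound 4 is estimated at 40% in this assay, within a range from 15% to 70%.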

Compound 4, a percentage reported as inhibition, at one concentration (the size of the read-out at that concentration, not a potency): 21%
Beside the measured number, compound 4's estimate is 19 percentage points above it; low and high end bracket the measured number.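

Read in this assay (3-hydroxyphenyl)amino in place of piperidin-1-yl on a carbonyl carbon gives the first readable step of the series (a number 8 percentage points lower from compound 1 to compound 4 (within the scatter)). On this carbonyl carbon, a non-aromatic ring without hydrogen-bond donors and an aromatic ring with them are therefore not separated by this read-out at the concentration tested. Nothing available accounts for this result. Still open, on these data alone, is whether a carboxylic acid or a longer alkyl chain in place of either group on this carbonyl carbon would separate from both.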